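Benzofuran amide replaces methoxyphenyl amide in a bisindole series

The source may hold more compounds than are shown below. What is called first, only, known or untested is meant among the compounds shown, and "the series" means these compounds.

Compound 3 `COc1ccc(C(=O)NC[C@H]2c3[nH]c4ccccc4c3C[C@H]3[C@H]4c5[nH]c6ccccc6c5C[C@@H]([C@H](C#N)N23)N4C)cc1` belongs to a set of three compounds sharing one core and differing only in the group attached to the side-chain nitrogen. In a functional assay on A2780 cells (Homo sapiens) for cytotoxicity, read by MTT assay, with a stated time of 72 h (a lower number here means a stronger inhibitor, a higher number a weaker inhibitor), compound 3 gives 320 nM, the highest of the three numbers. Compound 2 `CN1[C@@H]2c3[nH]c4ccccc4c3C[C@H]1[C@H](C#N)N1[C@@H](CNC(=O)c3cccc(C(F)(F)F)c3)c3[nH]c4ccccc4c3C[C@@H]21` gives 210 nM in this assay, and the step of a 1.5-fold higher number from compound 2 to compound 3 (0.18 log units; within the scatter) lies within the scatter. Compound 1 `CN1[C@@H]2c3[nH]c4ccccc4c3C[C@H]1[C@H](C#N)N1[C@@H](CN3C(=O)c4ccccc4C3=O)c3[nH]c4ccccc4c3C[C@@H]21` gives 80 nM in this assay, and the step of a 4.0-fold higher number from compound 1 to compound 3 (0.60 log units; beyond the scatter) lies beyond it.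

Compound 4 `CN1[C@@H]2c3[nH]c4ccccc4c3C[C@H]1[C@H](C#N)N1[C@@H](CNC(=O)c3cc4ccccc4o3)c3[nH]c4ccccc4c3C[C@@H]21` differs from compound 3 by 1-benzofuran-2-yl in place of 4-methoxyphenyl on a carbonyl carbon. Among the measured compounds shown here, the one step that bears on this change is the earlier exchange of one aromatic group for another on the same carbonyl carbon, a 1.5-fold higher number from compound 2 to compound 3 (0.18 log units; within the scatter), which stayed within the scatter. On that basis no step beyond the scatter is expected in this assay for compound 4, with a slight lean toward a lower number as seen for compound 2 210 nM. Compound 4 is therefore estimated at 250 nM in this assay, between 100 nM and 600 nM, a step of a 1.3-fold lower number from compound 3 to compound 4 (0.11 log units; within the scatter).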

Compound 4, half-maximal inhibitory concentration: 230 nM
Beside the measured number, compound 4's estimate is 1.1-fold (0.04 log units) above it; the range from low to high includes it.
By their numbers in this assay, from the lowest: compound 1; then compounds 2, 4 and 3 (each within the scatter of the next).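

In this assay, 1-benzofuran-2-yl on the carbonyl carbon gives a 1.4-fold lower number from compound 3 to compound 4 (0.14 log units; within the scatter), and in place of 3-(trifluoromethyl)phenyl it gives a 1.1-fold higher number from compound 2 to compound 4 (0.04 log units; within the scatter), so a group with a five-membered aromatic ring fused to the six-membered one is tolerated here as well as the single-ring aryl groups. The amide of compound 4 still does not reach compound 1, whose group carries a five-membered non-aromatic ring on the saturated chain carbon: the listed step is a 2.9-fold higher number from compound 1 to compound 4 (0.46 log units; beyond the scatter). Nothing available here accounts for these numbers.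

The compounds shown leave open whether a carbonyl substituent without an aromatic ring, such as cyclohexyl or a short alkyl chain, would stay within the scatter of these amides. They also leave open whether a basic amine on the aromatic group would move the number.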